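A few compounds are considered here, and "the series" means these few. Any claim that something is new, unique, unknown or untested is made for them only; others in the source may bear on it.

Values in a functional assay on SW 1116 cells (Homo sapiens) for cytotoxicity, read by MTT assay, with a stated time of 48 h (a lower number here means a stronger inhibitor, a higher number a weaker inhibitor), for the three measured compounds:

compound 1 `O=C(CSc1nnc(-c2ccncc2)o1)N/N=C/c1ccccc1` gives 16700 nM
compound 2 `O=C(CSc1nnc(-c2ccncc2)o1)N/N=C/c1cccc(F)c1` gives 26700 nM
compound 3 `O=C(CSc1nnc(-c2ccncc2)o1)N/N=C/c1ccccc1O` gives 7380 nM

Compound 3 holds the lowest number of the three. Its nearest neighbour is compound 1, separated by a 2.3-fold lower number from compound 1 to compound 3 (0.35 log units; beyond the scatter); the furthest is compound 2, separated by a 3.6-fold lower number from compound 2 to compound 3 (0.56 log units; beyond the scatter). Compound 1 and compound 2 differ only by a 1.6-fold higher number from compound 1 to compound 2 (0.20 log units; within the scatter).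

Compound 4 `O=C(CSc1nnc(-c2ccncc2)o1)N/N=C/c1cc(Cl)cc(Cl)c1O` has not yet been measured in this assay. It differs from compound 3 by 3,5-dichloro-2-hydroxyphenyl in place of 2-hydroxyphenyl on a carbon with a double bond to nitrogen. Within the data shown here, the only measured step that touches a halogen on an aromatic carbon is a 1.6-fold higher number from compound 1 to compound 2 (0.20 log units; within the scatter), which stayed within the scatter; no measured pair shows chlorine, or two halogens entering together, on the ring that carries the hydroxy. The hydroxy itself, kept in compound 4, went with a 2.3-fold lower number from compound 1 to compound 3 (0.35 log units; beyond the scatter). On this basis a small step is expected from compound 3 to compound 4, of uncertain direction, and the estimate leans slightly toward a lower number, as a 1.3-fold lower number from compound 3 to compound 4 (0.13 log units; within the scatter). Compound 4 is therefore expected to give about 5500 nM in this assay, with a range from 2000 nM to 16000 nM.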

Compound 4, half-maximal inhibitory concentration: 5030 nM
Compound 4: middle estimate off by 1.1-fold (0.04 log units), on the high side, within the range that was stated.
By their numbers in this assay, from the lowest: compounds 4 and 3 (each within the scatter of the next); then compounds 1 and 2 (each within the scatter of the next).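

In this assay, the step from 2-hydroxyphenyl to 3,5-dichloro-2-hydroxyphenyl on the carbon with a double bond to nitrogen is a 1.5-fold lower number from compound 3 to compound 4 (0.17 log units; within the scatter) and so does not separate the two compounds: this position accepts the two chlorines on the hydroxy-bearing ring with no change that can be read. Among these compounds, the dichloro group also stands clear of the two groups without hydroxy, with a 3.3-fold lower number from compound 1 to compound 4 (0.52 log units; beyond the scatter) against phenyl and a 5.3-fold lower number from compound 2 to compound 4 (0.72 log units; beyond the scatter) against 3-fluorophenyl, so among the four compounds both hydroxy-bearing groups give lower numbers than both groups without it, and no compound goes against this. No supporting data bear on the origin of these differences.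

The compounds shown leave open how a single chlorine on this ring would compare with the pair, and what the two chlorines would do in the absence of the hydroxy. They also leave open how a methoxy group, an amine or a carboxylic acid on this ring would read in this assay.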